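The compounds below may be only part of what the source reports. "The series", "measured", "known", "first", "only" and "open" are said of these compounds alone.

Series notes. The shared core is carried by compound 1 `Cc1ccccc1-n1nncc1CN1C(=O)C2(C(C#N)=C(N)Oc3c2c2nc4ccccc4nc2c2ccccc32)c2ccccc21`, compound 2 `N#CC1=C(N)Oc2c(c3nc4ccccc4nc3c3ccccc23)C12C(=O)N(Cc1cnnn1-c1cccc(Cl)c1)c1ccccc12`, compound 3 `N#CC1=C(N)Oc2c(c3nc4ccccc4nc3c3ccccc23)C12C(=O)N(Cc1cnnn1-c1cccc(S(N)(=O)=O)c1)c1ccccc12` and the as yet unmeasured compound 4 `Cc1ccc(C)c(-n2nncc2CN2C(=O)C3(C(C#N)=C(N)Oc4c3c3nc5ccccc5nc3c3ccccc43)c3ccccc32)c1`; the four differ only in the aryl group on an aromatic nitrogen. In an ADME assay on HUVEC cells (Homo sapiens) for antiproliferative activity, read by MTT assay, with a stated time of 48 h (on this read-out lower numbers stand for stronger inhibition and higher numbers for weaker inhibition), compound 1 gives > 50000 nM, which is a limit of the assay and not a number. Compound 2 likewise gives > 50000 nM in this assay, again a limit. Compound 3 gives 38600 nM in this assay. The step that the two limits leave unreadable from compound 1 to compound 2 is therefore unreadable, while an at least 1.2-fold lower number from compound 1 to compound 3 (0.11 log units; that floor lies within the scatter) and an at least 1.2-fold lower number from compound 2 to compound 3 (0.11 log units; that floor lies within the scatter) are floors lying within the scatter. The evidence in hand is the limit of > 50000 nM in this assay, at which 2 of the 3 values shown sit, and compound 1 stands at that limit.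

Compound 4 differs from compound 1 by methyl in place of hydrogen on an aromatic carbon. Among the measured compounds shown here, no measured step exchanges hydrogen for methyl, so none bears on this change directly; the readable steps in the set alter the aryl group and move the number no further than the scatter allows. No step beyond the scatter is therefore expected in this assay, and compound 4 is expected to remain at or near the limit. The estimate for compound 4 is 60000 nM, between 30000 nM and 150000 nM, which is an expected step that the limit leaves unreadable from compound 1 to compound 4.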

Compound 4, half-maximal inhibitory concentration: > 50000 nM
Compound 4: no number, only a limit (the forecaster's own chance of this, stated with the estimate: 80%); the middle value is on the limit's open side.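

In this assay compound 4 gives > 50000 nM, which is a limit of the assay and not a number. Among the compounds shown here, the steps to compound 4 from compound 1 and from compound 2 cannot be read, and the only readable step is an at least 1.2-fold higher number from compound 3 to compound 4 (0.11 log units; that floor lies within the scatter). Methyl on this aromatic carbon, meta to a large group and para to a methyl group, is the first change of hydrogen for methyl in the series, and the move from 2-methylphenyl to 2,5-dimethylphenyl gives no value clear of the limit that already held for compound 1: the limit of > 50000 nM in this assay, at which 3 of the 4 values shown sit.

The size of the methyl step stays open, as the compounds shown do not tell whether compound 1 and compound 4 lie close to the limit or far past it. Also open, on these data alone, is whether an amine or a carboxylic acid on the aryl ring, in the place of the sulfamoyl group of compound 3, would give a number separated from the limit by more than the scatter.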